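The source may hold more compounds than are shown below. What is called first, only, known or untested is meant among the compounds shown, and "the series" means these compounds.

In a functional assay on A549 cells (Homo sapiens) for inhibition, read by CCK-8 assay, with a stated time of 72 h, tested at 2 uM (a lower number here means less inhibition of growth, a higher number more inhibition of growth at the concentration tested), compound 1 `Nc1ccccc1NC(=O)/C=C/c1ccc(CSc2ccc(Cl)cc2)cc1` gives 55.3%, compound 2 `CCc1ccc(SCc2ccc(C(=O)Nc3ccccc3N)cc2)cc1` gives 53.6% and compound 3 `Nc1ccccc1NC(=O)c1ccc(CSc2cccc(F)c2)cc1` gives 46.9%. Compound 3 therefore stands within the usual scatter of the other two, and these numbers do not separate it from them.

The next compound to be tested is compound 4 `Nc1ccccc1NC(=O)c1ccc(CSc2ccc(Br)cc2)cc1`. The change is 4-bromophenyl in place of 3-fluorophenyl on a sulfur, which puts 4-bromophenyl in place of 3-fluorophenyl on a sulfur. Going by the values given here, only one measured step bears on this place: a number 6.7 percentage points lower from compound 2 to compound 3 (within the scatter), where 3-fluorophenyl replaces 4-ethylphenyl on a sulfur. Among the compounds with values here, that step is small, and no measured compound yet carries 4-bromophenyl, so the data give no firm direction for the new change. A shift beyond the scatter is not expected. The expected result is a number 4.1 percentage points higher from compound 3 to compound 4 (within the scatter), which would stay within the scatter. Compound 4 is estimated at 51%, with an expected range from 39% to 63%.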

Compound 4, percent growth inhibition at one concentration: 33.2%
Compound 4: middle estimate off by 17.8 percentage points, on the high side; measured number below the stated range.
By their numbers in this assay, from the lowest: compound 4; then compounds 3, 2 and 1 (each within the scatter of the next).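

In this assay the aryl group on the sulfur now proves able to move the number: the earlier step at this place stayed within the scatter, whereas a number 13.7 percentage points lower from compound 3 to compound 4 (beyond the scatter) lies beyond it, with 4-bromophenyl in place of 3-fluorophenyl. The second comparison, a number 20.4 percentage points lower from compound 2 to compound 4 (beyond the scatter), with bromo in place of ethyl on an aromatic carbon, also lies beyond the scatter. A change of the aromatic substituent alone is therefore enough to lower growth inhibition at the concentration tested.

The step from 3-fluorophenyl to 4-bromophenyl changes both the halogen and its place on the ring, and the compounds shown do not separate these two changes. They also leave open whether a methoxy group or an amine in place of bromo would give a number nearer to that of the ethyl compound or the bromo compound. Nothing measured here accounts for the lower number given by the bromo compound.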